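Swapping an aromatic amide group for cyclopropyl

This account rests on a few compounds, and the source may have more. Where it says the series, first, only, none or still open, it means among the compounds named here.

Measured in an in vitro ADME assay on microsomes from liver (Homo sapiens) for pharmacokinetics, read by LC-MS, with a stated time of 10 min, tested at 1 uM; a higher number here means faster removal of the compound, a lower number slower removal:
compound 1 `COc1cccc(NC(=O)[C@H]2CN(C)C[C@@H]2c2ccc(/C=C/C(=O)Nc3ccccc3N)cc2)c1`: 14 mL/min/kg
compound 2 `CN1C[C@H](C(=O)Nc2ccc(F)c(Cl)c2)[C@@H](c2ccc(/C=C/C(=O)Nc3ccccc3N)cc2)C1`: 15 mL/min/kg
compound 3 `CN1C[C@H](C(=O)Nc2ccc(Cl)cn2)[C@@H](c2ccc(/C=C/C(=O)Nc3ccccc3N)cc2)C1`: 13 mL/min/kg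

Compound 3 does not stand apart from the other two, as the data show a 1.1-fold lower number from compound 1 to compound 3 (0.03 log units; within the scatter) and a 1.2-fold lower number from compound 2 to compound 3 (0.06 log units; within the scatter). The next structure, compound 4 `CN1C[C@H](C(=O)NC2CC2)[C@@H](c2ccc(/C=C/C(=O)Nc3ccccc3N)cc2)C1`, carries cyclopropyl in place of 5-chloropyridin-2-yl on an amide-type nitrogen. For the measured compounds named here, the steps that bear on this change are those two and a 1.1-fold higher number from compound 1 to compound 2 (0.03 log units; within the scatter), all exchanges on that same nitrogen. Each replaced one aromatic ring with another, so none tests a three-membered non-aromatic ring. A step beyond the scatter in this assay is therefore not expected, though this is uncertain. The expected step is a 1.1-fold lower number from compound 3 to compound 4 (0.03 log units; within the scatter). For compound 4 the estimated clearance is 12 mL/min/kg, with an expected range from 7 mL/min/kg to 19 mL/min/kg.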

Compound 4, clearance: 10 mL/min/kg
The estimate for compound 4 lay 1.2-fold (0.08 log units) above the measured number, within the range that was stated.
By their numbers in this assay, from the lowest: compounds 4, 3, 1 and 2 (each within the scatter of the next).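

In this assay, for the compounds shown here, cyclopropyl, the only non-aromatic group here on this amide-type nitrogen, stays within the scatter of the 5-chloropyridin-2-yl compound (a 1.3-fold lower number from compound 3 to compound 4 (0.11 log units; within the scatter)), the 3-chloro-4-fluorophenyl compound (a 1.5-fold lower number from compound 2 to compound 4 (0.18 log units; within the scatter)) and the 3-methoxyphenyl compound (a 1.4-fold lower number from compound 1 to compound 4 (0.15 log units; within the scatter)). The number at this position therefore does not move beyond the scatter even when an aromatic ring gives way to a three-membered ring of carbon only, with 3 heavy atoms entering and 7 leaving. Nothing measured here offers a reason for this result.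

On these data alone, whether an open-chain ethyl group, an amine or a carboxylic acid on this nitrogen would also stay within the scatter remains open.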